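Two cores, one added chloro group, and an expected outcome

The source may report more compounds than this note shows. Statements on the series, on what has been measured and on what is new or still open speak of the compounds shown alone.

The study compares two arrangements of the same atoms. Compound 1 `O=S1(=O)C=Cc2ccc(Nc3ccc(Cl)cc3)cc21` and compound 3 `O=S1(=O)C=Cc2cccc(Nc3ccc(Cl)cc3)c21` share every atom but join them differently; the difference between the two cores is not broken down here. In a functional assay on MCF7 cells (Homo sapiens) for antiproliferative activity, read by MTT assay, with a stated time of 72 h (on this read-out higher numbers stand for weaker inhibition and lower numbers for stronger inhibition), compound 1 gives 2670 nM, and compound 3 gives 680 nM, which stands lowest among the three measured numbers, beyond the scatter from both others.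

Compound 2 `O=S1(=O)C=Cc2ccc(Nc3ccc(Cl)c(Cl)c3)cc21` carries the change chloro in place of hydrogen on an aromatic carbon on the core of compound 1. In this assay compound 2 gives 2230 nM, so that a 1.2-fold lower number from compound 1 to compound 2 (0.08 log units; within the scatter).

Compound 4 `O=S1(=O)C=Cc2cccc(Nc3ccc(Cl)c(Cl)c3)c21` carries the same change on the core of compound 3, namely (chloro in place of hydrogen on an aromatic carbon). The surroundings of the new group read the same in both cases, so the change is the same one, made on a different core, and it occurs twice among the compounds shown.

The expectation for compound 4 rests on one pair only. Because the step of a 1.2-fold lower number from compound 1 to compound 2 (0.08 log units; within the scatter) stayed within the scatter, the step from compound 3 is expected to be similarly small, a 1.2-fold lower number from compound 3 to compound 4 (0.07 log units; within the scatter), starting from compound 3 at 680 nM. Compound 4 is therefore estimated at 580 nM, with the likely range running from 290 nM to 1200 nM.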

Compound 4, half-maximal inhibitory concentration: 570 nM
Beside the measured number, compound 4's estimate is 1.0-fold (0.01 log units) above it, and the stated range covers the measured number.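

In this assay the added chloro group gives a 1.2-fold lower number from compound 3 to compound 4 (0.08 log units; within the scatter), and set beside the earlier step on the other core, the two agree: the same change on two cores in this assay, a 1.2-fold lower number (0.08 log units; within the scatter) from compound 1 to compound 2 and a 1.2-fold lower number (0.08 log units; within the scatter) from compound 3 to compound 4, 1.0-fold (0.00 log units) apart, within the scatter of two such steps. Within this series, then, the change carries from one core to the other as a step that stays inside the scatter on both, and the core it is made on leaves no mark on its size. This does not show that the change would carry in the same way to any further core or in any other read-out, since it rests on two pairs in a single assay, and a step too small to stand out from the scatter is a weak test of transfer, so it says nothing about how a larger step would travel between these cores.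

The compounds shown leave open whether a different group in the same place, such as methoxy, trifluoromethyl or an amine, would give a step beyond the scatter, and whether such a step would then match on the two cores. They also leave open what a carboxylic acid or a longer chain elsewhere on the aromatic ring would do on either core.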